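Sulfonyl and carbonyl caps on the piperazine of the benzofuran ketone

The compounds below may be only part of what the source reports. "The series", "measured", "known", "first", "only" and "open" are said of these compounds alone.

Measured compounds:
- compound 1 `CCN(CC)c1ccc2cc(C(=O)c3ccc(N4CCN(C(=O)COc5ccc(Cl)cc5Cl)CC4)cc3)oc2c1` — 12400 nM
- compound 2 `CCN(CC)c1ccc2cc(C(=O)c3ccc(N4CCN(S(=O)(=O)c5ccc([N+](=O)[O-])cc5)CC4)cc3)oc2c1` — > 40000 nM
- compound 3 `CCOC(=O)N1CCN(c2ccc(C(=O)c3cc4ccc(N(CC)CC)cc4o3)cc2)CC1` — > 40000 nM

In a functional assay on MCF7 cells (Homo sapiens) for cytotoxicity, read by MTT assay, with a stated time of 48 h (a higher number here means a weaker inhibitor, a lower number a stronger inhibitor), compound 1 gives 12400 nM. For compound 2 the value > 40000 nM is a limit of the assay, not a number. For compound 3 the value > 40000 nM is likewise a limit of the assay. Compound 3 therefore stands at the weak end of what is shown, as does compound 2, since (the limit of > 40000 nM in this assay, at which 2 of the 3 values shown sit).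

The step to compound 4 `CCN(CC)c1ccc2cc(C(=O)c3ccc(N4CCN(S(=O)(=O)c5ccc(F)cc5)CC4)cc3)oc2c1` is (4-fluorophenyl)sulfonyl in place of ethoxycarbonyl on an amine nitrogen in a ring. Going by the values given here, two measured steps bear on it. Among the compounds with values here, the step of an at least 3.2-fold higher number from compound 1 to compound 3 (0.50 log units; beyond the scatter) and the step of an at least 3.2-fold higher number from compound 1 to compound 2 (0.50 log units; beyond the scatter) both move from the one numbered value to the limit. The step that the two limits leave unreadable from compound 2 to compound 3 is between two limits and cannot be read. Within the data shown here, compound 4 carries an arylsulfonyl cap as compound 2 does, and compound 2 sits at the limit; no measured step shows a sulfonyl cap giving a number within range in this assay.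

Compound 4 is therefore expected to stay near the limit, at an estimated 50000 nM (range 15000 nM to 150000 nM), an expected step that the limit leaves unreadable from compound 3 to compound 4.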

Compound 4, half-maximal inhibitory concentration: 21700 nM
For compound 4 the middle estimate is 2.3-fold (0.36 log units) above the measured one; measured number inside the range.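

In this assay compound 4 shows that an arylsulfonyl cap on this amine nitrogen can give a number inside the assay's range, which compound 2, also capped with an arylsulfonyl group, did not show. Set against the carbonyl cap of compound 1, the (4-fluorophenyl)sulfonyl cap gives a difference within the scatter (a 1.8-fold higher number from compound 1 to compound 4 (0.24 log units; within the scatter)), so these two caps are not told apart here. Fluoro in place of nitro (an at least 1.8-fold lower number from compound 2 to compound 4 (0.26 log units; that floor lies within the scatter)) and (4-fluorophenyl)sulfonyl in place of ethoxycarbonyl (an at least 1.8-fold lower number from compound 3 to compound 4 (0.26 log units; that floor lies within the scatter)) both have floors within the scatter, and their true sizes stay unknown because of the limit: the limit of > 40000 nM in this assay, at which 2 of the 4 values shown sit.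

The step between compound 2 and compound 3 cannot be read. Open, as far as these compounds go, is how an amine or a carboxylic acid in place of fluoro on the aromatic carbon would read in this assay.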